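Chloropyridinylmethyl ether series: amine substituent and cellular inhibition

The source may report more compounds than this note shows. Statements on the series, on what has been measured and on what is new or still open speak of the compounds shown alone.

Measured so far:
compound 1 `COc1cc(CNCc2ccncc2)ccc1OCc1cccc(F)c1` — 4800 nM
compound 2 `COc1cc(CNCc2ccccc2)ccc1OCc1ccc(Cl)nc1` — 90000 nM
compound 3 `COc1cc(CNCCCN(C)C)ccc1OCc1ccc(Cl)nc1` — 5000 nM

In a functional assay on HeLa cells (Homo sapiens) for inhibition, with a stated time of 72 h (on this read-out higher numbers stand for an effect only at larger amounts of compound and lower numbers for an effect already at smaller amounts), compound 3 stands second highest of the three numbers. Its nearest neighbour is compound 1, within the scatter; its furthest is compound 2, beyond it. Among the compounds with values here, the one single-point step available is an 18-fold lower number from compound 2 to compound 3 (1.26 log units; beyond the scatter), where 2-(dimethylamino)ethyl in place of phenyl on a saturated chain carbon bound to an amine nitrogen gave a large drop.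

Compound 4 `COc1cc(CNCc2ccncc2)ccc1OCc1ccc(Cl)nc1` is not yet measured. Its difference from compound 3 is pyridin-4-yl in place of 2-(dimethylamino)ethyl on a saturated chain carbon bound to an amine nitrogen. Within the data shown here, the pyridin-4-yl group entering here is the one carried by compound 1, where the ether side differs, so no clean step links compound 1 to compound 4. Among the measured compounds shown here, the only guide is the step to compound 3, which reverses in part: an aromatic ring returns in place of the 2-(dimethylamino)ethyl chain, though a ring bearing a hetero atom rather than the phenyl of compound 2. A moderate rise in the number is therefore expected, estimated as a 3.0-fold higher number from compound 3 to compound 4 (0.48 log units; beyond the scatter). Compound 4 is expected at 15000 nM, range 4000 nM to 60000 nM.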

Compound 4, half-maximal effective concentration: 400 nM
Beside the measured number, compound 4's estimate is 38-fold (1.57 log units) above it; the measured number lies below the stated range.
By their numbers in this assay, from the lowest: compound 4; then compounds 1 and 3 (each within the scatter of the next); then compound 2.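

In this assay, pyridin-4-yl in place of phenyl on the amine side gives a 230-fold lower number from compound 2 to compound 4 (2.35 log units; beyond the scatter) and, in place of 2-(dimethylamino)ethyl, gives a 13-fold lower number from compound 3 to compound 4 (1.10 log units; beyond the scatter) at the same position. Compounds 2 and 4 both carry a six-membered aromatic ring here, so the presence of an aromatic ring alone does not set the number; the identity of the ring does. The ether side also responds, as 6-chloropyridin-3-yl in place of 3-fluorophenyl gives a 12-fold lower number from compound 1 to compound 4 (1.08 log units; beyond the scatter) with pyridin-4-yl held constant.

On these data alone, whether a pyrimidine ring, a piperidine ring or a longer chain on the amine side would keep the number of compound 4 remains open. As far as these compounds go, it is also open whether the ether-side step would hold with phenyl or 2-(dimethylamino)ethyl on the amine side. Nothing shown explains these steps.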